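This account rests on a few compounds, and the source may have more. Where it says the series, first, only, none or still open, it means among the compounds named here.

Of the compounds shown here, three on a shared core have been read in an ADME assay on microsomes from liver (Mus musculus) for metabolic stability, read by LC-MS, with NADPH named in the record, with a stated time of 60 min, tested at 1 uM, in the absence of a further agent; on this read-out lower numbers stand for a less stable compound and higher numbers for a more stable compound: compound 1 (`COc1ccc(-c2c(C)nc3c(N4CC[C@@H](NS(=O)(=O)C(C)C)C4)cc(C)nn23)cc1OC`) carries isopropyl on the sulfonyl sulfur, compound 2 (`COc1ccc(-c2c(C)nc3c(N4CC[C@@H](NS(=O)(=O)c5ccc(C)cc5)C4)cc(C)nn23)cc1OC`) carries 4-methylphenyl there, and compound 3 (`COc1ccc(-c2c(C)nc3c(N4CC[C@@H](NS(=O)(=O)c5ccc(NC(C)=O)cc5)C4)cc(C)nn23)cc1OC`) carries 4-acetamidophenyl. Compound 1 gives > 95%, which is a limit of the assay and not a number. Compound 2 gives > 95%, again a limit. Compound 3, the starting point here, gives > 95%, also a limit, so its exact place is not known. Compound 4 (`COc1ccc(-c2c(C)nc3c(N4CC[C@@H](NS(=O)(=O)c5ccc(C(F)(F)F)cc5)C4)cc(C)nn23)cc1OC`) has trifluoromethyl in place of acetamido on an aromatic carbon. For the measured compounds named here, three measured steps bear on this change: a step that the two limits leave unreadable from compound 1 to compound 2, a step that the two limits leave unreadable from compound 1 to compound 3 and a step that the two limits leave unreadable from compound 2 to compound 3. All three compounds share one result, (the limit of > 95% in this assay, at which 3 of the 3 values shown sit). Trifluoromethyl itself has not been measured in this set, so the steps give no direct reading for it. Going by the values given here, compound 4 is nevertheless expected to stay close to compound 3 because a step that the two limits leave unreadable from compound 2 to compound 3 is the nearest precedent, at the same aromatic carbon. No change beyond the scatter is expected in this assay, in either direction. The step estimated is a number no higher from compound 3 to compound 4 (the limit leaves the size open). For compound 4 the estimated value is 95%, with an expected range from 84% to 100%.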

Compound 4, percent of the compound remaining: > 95%
Compound 4 ended at the assay's limit; the forecaster's own chance of this, stated with the estimate: 60%; the middle value sits exactly at the limit.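

No new step can be read between compound 4 and compound 1, compound 2 or compound 3, because all four compounds sit at one limit of the assay, not at a number: the limit of > 95% in this assay, at which 4 of the 4 values shown sit.

The compounds shown leave open how far they truly differ in this assay, and whether any group on the sulfonyl sulfur changes the percent remaining.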